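A few compounds are considered here, and "the series" means these few. Any claim that something is new, unique, unknown or untested is made for them only; others in the source may bear on it.

In a functional assay on L1210 cells (Mus musculus) for cytotoxicity (on this read-out lower numbers stand for stronger inhibition and higher numbers for weaker inhibition), three compounds have been measured so far:

Compound 1 `C=C1C(n2cc(Cl)c(=O)[nH]c2=O)O[C@H](CO)[C@@H]1O`: > 100 ug/mL, a limit of the assay, not a number.
Compound 2 `C=C1C(n2cc(Br)c(=O)[nH]c2=O)O[C@H](CO)[C@@H]1O`: > 100 ug/mL, again only a limit.
Compound 3 `C=C1C(n2cc(Cl)c(N)nc2=O)O[C@H](CO)[C@@H]1O`: > 100 ug/mL, also a limit.

Compound 2 differs from compound 1 by one change, (bromo in place of chloro on an aromatic carbon). The step that the two limits leave unreadable from compound 1 to compound 2 cannot be read, because both values sit at the limit of > 100 ug/mL in this assay, at which 3 of the 3 values shown sit. Compound 3 carries a different core from compound 1; the difference between the two cores is not broken down here.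

Compound 4 `C=C1C(n2cc(Br)c(N)nc2=O)O[C@H](CO)[C@@H]1O` has not yet been measured in this assay. It differs from compound 3 by bromo in place of chloro on an aromatic carbon. For the measured compounds named here, this is the same kind of change as the one from compound 1 to compound 2, though the surroundings are not identical: in compound 1 the changed carbon is ortho to a group of 1 heavy atom, whereas in compound 3 it is ortho to an amino group (1 heavy atom).

For the new pair the expected step is a step that the limit leaves unreadable from compound 3 to compound 4; this expectation rests on compound 3 giving > 100 ug/mL and on the earlier pair, where compound 1 and compound 2 both sit at the limit of > 100 ug/mL in this assay, at which 3 of the 3 values shown sit, so that their step is unreadable. Compound 4 is therefore estimated at 150 ug/mL, with a plausible range from 40 ug/mL to 600 ug/mL, and is most likely to be reported only as a limit in this assay.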

Compound 4, half-maximal inhibitory concentration: > 100 ug/mL
Compound 4: no number, only a limit (the forecaster's own chance of this, stated with the estimate: 85%); the middle value lies beyond the limit too.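

In this assay compound 4 gives > 100 ug/mL, which is a limit and not a number. The step from compound 3 to compound 4, bromo in place of chloro, therefore cannot be read: the limit of > 100 ug/mL in this assay, at which 4 of the 4 values shown sit. The compounds shown leave open what actual values any of them would have in this assay, and whether bromo and chloro differ at all on this read-out.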